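Changing the amide cap of a chemokine receptor antagonist

This account rests on a few compounds, and the source may have more. Where it says the series, first, only, none or still open, it means among the compounds named here.

Three sulfonamides sharing one core have been measured in a functional assay on CHO cells for antagonist activity at C-C chemokine receptor type 4 (Homo sapiens), read by GTPgammaS binding; a lower number here means a stronger inhibitor, a higher number a weaker inhibitor. Compound 1 `CC(=O)NCc1cccc(Cn2nc(NS(=O)(=O)c3ccc(Cl)s3)c3c(CO)cccc32)c1` gives 6.31 nM, compound 2 `CC(=O)NCc1cccc(Cn2nc(NS(=O)(=O)c3ccc(Cl)s3)c3c(C(C)=O)cccc32)c1` gives 100 nM, and compound 3 `COc1cccc2c1c(NS(=O)(=O)c1ccc(Cl)s1)nn2Cc1cccc(CNC(=O)C2CCCO2)c1` gives 39.8 nM. Compound 3 therefore stands second of the three, with a lower number than compound 2 and a higher number than compound 1. Among the compounds with values here, the only single-point step among the measured compounds is a 16-fold higher number from compound 1 to compound 2 (1.20 log units; beyond the scatter), and it concerns the substituent on the aromatic carbon of the core, not the amide cap.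

Compound 4 `CN[C@H](C)C(=O)NCc1cccc(Cn2nc(NS(=O)(=O)c3ccc(Cl)s3)c3c(OC)cccc32)c1` differs from compound 3 at that cap: 1-(methylamino)ethyl in place of oxolan-2-yl on a carbonyl carbon. Within the data shown here, no measured step touches this position, so the step from compound 1 to compound 2 does not bear on it directly; it only shows that this series can move well beyond the scatter when one group is exchanged. With nothing measured on the amide cap, the expected step is a 1.2-fold lower number from compound 3 to compound 4 (0.09 log units; within the scatter), and that expectation carries wide uncertainty in both directions. Compound 4 is accordingly estimated at 32 nM in this assay, within a range from 8 nM to 130 nM.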

Compound 4, half-maximal inhibitory concentration: 15.9 nM
For compound 4 the middle estimate is 2.0-fold (0.30 log units) above the measured one; the measured number falls inside the stated range.
By their numbers in this assay, from the lowest: compound 1; then compound 4; then compound 3; then compound 2.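

The amide cap turns out to be a position that responds to change: in this assay, 1-(methylamino)ethyl in place of oxolan-2-yl on a carbonyl carbon gives a 2.5-fold lower number from compound 3 to compound 4 (0.40 log units; beyond the scatter). Within the data shown here, this is the first measured step at the cap, and it shows that the cap need not be a ring, since an open group keeps the compound active and lowers the number beyond the scatter. The exchange alters several things at once: a five-membered non-aromatic ring leaves, while 1 hydrogen-bond donor and 1 defined stereocentre enter, so this single step cannot assign the change in number to any one of them. No measurement presented here explains why the number moves.

The compounds shown leave open whether the methylamino nitrogen itself matters, which a hydroxyl or a plain methyl in its place would test, and whether a dimethylamino group or a free amine would do the same. They also leave open how the opposite form of the stereocentre would read, and whether a longer chain or a six-membered ring on the same carbonyl carbon would move the number further.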